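A Methoxy Added on the Chain of Compound 3

The source may report more compounds than this note shows. Statements on the series, on what has been measured and on what is new or still open speak of the compounds shown alone.

Of the compounds shown here, three have been tested in a functional assay on RAW264.7 cells (Mus musculus) for inhibition, read by Griess assay, with stated times of 1 h and 24 h; on this read-out higher numbers stand for weaker inhibition and lower numbers for stronger inhibition. Compound 1 `O=C1OC(Cc2nc(-c3ccc(Oc4ccccc4)cc3)no2)c2ccccc21` gives only a limit in this assay, > 10000 nM. Compound 2 `O=C1OC(Cc2nc(-c3ccc(-c4ccccc4)cc3)no2)c2ccccc21` likewise gives only a limit in this assay, > 10000 nM. The step that the two limits leave unreadable from compound 1 to compound 2 therefore cannot be read. For the measured compounds named here, compound 3 `CCCCOc1ccc(C(O)C2OC(=O)c3c(OC)cc(OC)cc32)cc1` is the only compound with a measured number, 1800 nM in this assay. Compound 4 `COCCCCOc1ccc(C(O)C2OC(=O)c3c(OC)cc(OC)cc32)cc1` differs from compound 3 by methoxy in place of hydrogen on a saturated chain carbon, four bonds along the chain from an oxygen on an aromatic ring. None of the measured steps involves this kind of change, so no shown step bears on it, and no movement beyond the usual scatter is expected in this assay. The expected step is no change at the digits printed from compound 3 to compound 4 (within the scatter). Compound 4 is therefore estimated at 1800 nM, within 600 nM to 5400 nM.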

Compound 4, half-maximal inhibitory concentration: 8210 nM
For compound 4 the middle estimate is 4.6-fold (0.66 log units) below the measured one, outside the stated range (above it).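

For the compounds shown here, the first readable step in this assay is a 4.6-fold higher number from compound 3 to compound 4 (0.66 log units; beyond the scatter). It shows that this chain position is not indifferent: methoxy in place of hydrogen, four bonds along the chain from an oxygen on an aromatic ring, weakens inhibition beyond the scatter. This is a single change at a single place, so it sets no trend.

As far as these compounds go, whether a hydroxyl, an amine, a carboxylic acid or a longer chain at this place would weaken inhibition too remains open. Any much weaker compound could not be sized, since readings in this assay end at a limit: the limit of > 10000 nM in this assay, at which 2 of the 4 values shown sit.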